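Isobutyl in place of cyclobutyl on the shared core

The source may hold more compounds than are shown below. What is called first, only, known or untested is meant among the compounds shown, and "the series" means these compounds.

In an ADME assay on a cell-free system (plasma, Rattus norvegicus) for metabolic stability, read by LC-MS, with a stated time of 1 h, at 37 degrees C, tested at 100 uM (a higher number here means that more of the compound is left, a lower number that less of the compound is left), compound 1 `O=C(O)c1cc(-c2cccc(COc3ccc4c(=O)n(CC5CC5)sc4c3)c2)ccc1Cl` gives 100%, compound 2 `O=C(O)c1cc(-c2cccc(COc3ccc4c(=O)n(C5CCC5)sc4c3)c2)ccc1Cl` gives 91% and compound 3 `O=C(O)c1ccc(-c2cccc(COc3ccc4c(c3)CN(C3CCCC3)C4=O)c2)c(Cl)c1` gives 100%. Compound 2 thus lies within the scatter of both other compounds, and the three numbers set up no order.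

Compound 4 `CC(C)Cn1sc2cc(OCc3cccc(-c4ccc(Cl)c(C(=O)O)c4)c3)ccc2c1=O` has isobutyl in place of cyclobutyl on an aromatic nitrogen. The carbon count of the group stays the same, but its ring is gone.

Among the compounds with values here, only one measured step bears on this change, as it concerns the same aromatic nitrogen: a number 9 percentage points lower from compound 1 to compound 2 (within the scatter). That step, cyclobutyl in place of cyclopropylmethyl, stays within the scatter. Within the data shown here, no isobutyl compound has been measured, so this support is indirect.

No step beyond the scatter is therefore expected in this assay. The expected step is a number 4 percentage points higher from compound 2 to compound 4 (within the scatter), which is within the scatter. Compound 4 is estimated at 95%, with an expected range of 82% to 100%.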

Compound 4, percent of the compound remaining: 95%
Estimate against measurement, compound 4: no gap at the digits printed; measured number inside the range.
By their numbers in this assay, from the lowest: compounds 2, 4, 1 and 3 (each within the scatter of the next).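

Isobutyl in place of cyclobutyl gives a number 4 percentage points higher from compound 2 to compound 4 (within the scatter) in this assay and so adds an open-chain group to the ring-bearing groups on this aromatic nitrogen, with no step beyond the scatter. Against the cyclopropylmethyl group, isopropyl in place of cyclopropyl on the saturated chain carbon gives a number 5 percentage points lower from compound 1 to compound 4 (within the scatter) and so also stays within the scatter, which means that cyclobutyl, cyclopropylmethyl and isobutyl cannot be told apart at this position. No measurement that would explain these numbers is at hand.

On these data alone, whether this holds for much larger or more polar groups on the same nitrogen, such as a long n-octyl chain or an aminoethyl chain, stays open. Also open, as far as these compounds go, is whether any such group would give a step beyond the scatter in this assay at all.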